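The source may report more compounds than this note shows. Statements on the series, on what has been measured and on what is new or still open speak of the compounds shown alone.

Measured in a functional assay on Lu cells (Homo sapiens) for antiproliferative activity; a higher number here means a weaker inhibitor, a lower number a stronger inhibitor:
compound 1 `COc1ccc(/C=C/C(=O)c2ccc(OCCn3cc(CN4C(=O)/C=C/C(C)(C)C/C=C(\C)CC/C=C/4C)nn3)cc2O)cc1`: 1.67 ug/mL
compound 2 `C/C1=C\CC(C)(C)/C=C/C(=O)N(Cc2cn(CCOc3ccc(C(=O)/C=C/c4ccc(C)cc4)c(O)c3)nn2)/C(C)=C/CC1`: 0.91 ug/mL
compound 3 `COc1cccc(/C=C/C(=O)c2ccc(OCCCN3C(=O)/C=C/C(C)(C)C/C=C(\C)CC/C=C/3C)cc2)c1`: 1.06 ug/mL

Compound 3 stands second highest of the three numbers in this assay; its nearest neighbour is compound 2 and its furthest is compound 1, and both of those gaps lie within the scatter, so nothing separates the three measured compounds here. Compound 4 `COc1cc(/C=C/C(=O)c2ccc(OCCCN3C(=O)/C=C/C(C)(C)C/C=C(\C)CC/C=C/3C)cc2)cc(OC)c1OC` differs from compound 3 in one place: 3,4,5-trimethoxyphenyl in place of 3-methoxyphenyl on a double-bonded chain carbon bound to a double-bonded chain carbon. Among the measured compounds shown here, only one measured step exists, and it bears on the same aromatic ring: a 1.8-fold lower number from compound 1 to compound 2 (0.26 log units; within the scatter). For the measured compounds named here, that step, a swap of one small group for another, stayed within the scatter, but no measured pair shows what two added methoxy groups do on this ring, so the expectation rests on the single step alone. He therefore expects no step beyond the scatter in this assay, with the estimated change being a 1.1-fold lower number from compound 3 to compound 4 (0.03 log units; within the scatter). For compound 4 in this assay he estimates 1 ug/mL, within a range from 0.4 ug/mL to 2.5 ug/mL.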

Compound 4, half-maximal inhibitory concentration: 1.01 ug/mL
The estimate for compound 4 lay 1.0-fold (0.00 log units) below the measured number; low and high end bracket the measured number.
By their numbers in this assay, from the lowest: compounds 2, 4, 3 and 1 (each within the scatter of the next).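

In this assay the exchange of 3-methoxyphenyl for 3,4,5-trimethoxyphenyl gave a 1.0-fold lower number from compound 3 to compound 4 (0.02 log units; within the scatter). This is the first step shown at this place, on a double-bonded chain carbon bound to a double-bonded chain carbon, and it shows that a group of 12 heavy atoms with 3 hydrogen-bond acceptors, entering for one of 8 heavy atoms with 1 acceptor, does not separate the two compounds in this assay, whereas the earlier step covered only the exchange of one small group for another. No measurement at hand offers a reason for this result.

On these data alone, what an amine or a carboxylic acid on this aromatic ring would do remains open. So does the effect of the chain joining the shared core to the rest of the molecule, since no pair shown differs in that place alone.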